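Notes on cationic side-chain variants of the shared core

This account rests on a few compounds, and the source may have more. Where it says the series, first, only, none or still open, it means among the compounds named here.

Measured so far:
compound 1 `Cc1cc(OCCCCCCC[N+]23CCN(CC2)CC3)cc(-n2cc(C(=O)Nc3cc(F)cc(F)c3)c(=O)c3ccc(N(C)C)nc32)c1` — 10.3%
compound 2 `CN(C)c1ccc2c(=O)c(C(=O)Nc3cc(F)cc(F)c3)cn(-c3ccc(Cl)c(OCCCCCCC[N+]45CCN(CC4)CC5)c3)c2n1` — 8.08%
compound 3 `CN(C)c1ccc2c(=O)c(C(=O)Nc3cc(F)cc(F)c3)cn(-c3ccc(OCCCCCCC[N+]4(C)CCCC4)cc3Cl)c2n1` — "not active" (no number reported)

In an assay on LX2 cells for inhibition of COL1A1 promoter (Homo sapiens), read by a luciferase reporter, with a stated time of 24 h, tested at 20 uM (a higher number here means a stronger effect of the compound at the concentration tested, a lower number a weaker effect), compound 1 gives 10.3%. In this assay compound 2 gives 8.08%, and the two numbers lie within the usual scatter of each other, so nothing separates compound 1 from compound 2 on this read-out. Among the compounds with values here, compound 3 is reported in this assay as "not active" (no number reported), with no number attached, so it gives no step to compare. Within the data shown here, all three measured compounds carry a charged group at the end of a seven-carbon chain on an aromatic oxygen, and none of the measured pairs differs in a single place, so no step between measured compounds is available.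

Compound 4 `Cc1cc(OCCCCCCC[n+]2ccccc2)cc(-n2cc(C(=O)Nc3cc(F)cc(F)c3)c(=O)c3ccc(N(C)C)nc32)c1` differs from compound 1 in one place: a group of 6 heavy atoms (5 carbon, 1 nitrogen; one six-membered aromatic ring with 1 hetero atom) in place of a group of 8 heavy atoms (6 carbon, 2 nitrogen; 2 six-membered non-aromatic rings with 2 hetero atoms each), on a saturated chain carbon, seven bonds along the chain from an oxygen on an aromatic ring. The charge is kept and the chain is unchanged, while the charged end group becomes aromatic.

With the three measured compounds all at weak or absent inhibition, a step from compound 1 to compound 4 of no more than the scatter is expected, in no particular direction: a number 0.3 percentage points lower from compound 1 to compound 4 (within the scatter). For compound 4 in this assay the expected value is 10%, with a range from 0% to 22%.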

Compound 4, a percentage reported as inhibition, at one concentration (the size of the read-out at that concentration, not a potency): 7.7%
Compound 4: the middle estimate sits 2.3 percentage points above what was measured, within the range that was stated.
By their numbers in this assay, from the lowest: compounds 4, 2 and 1 (each within the scatter of the next).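

In this assay the series now has its first step at a single place, and it reads a number 2.6 percentage points lower from compound 1 to compound 4 (within the scatter) when a group of 6 heavy atoms (one six-membered aromatic ring with 1 hetero atom) takes the place of a group of 8 heavy atoms (2 six-membered non-aromatic rings with 2 hetero atoms each), on a saturated chain carbon, seven bonds along the chain from an oxygen on an aromatic ring. With the chain, the shared core and the net charge of +1 held constant, this exchange of end groups therefore leaves compound 1 and compound 4 unseparated on this read-out, a statement that covers this one pair and no other end group. No further measurement bears on this result.

Still open, going by these compounds, is whether an end group without a permanent charge, such as a primary amine or a carboxylic acid, would give a read-out beyond the scatter of compound 1 at this position. A longer chain carrying the same aromatic end group as compound 4 would test whether the chain length, rather than the end group, governs the read-out in this series.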